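Replacing an oxime ether on the aryl ring: a hydroxyalkyl variant

The source may report more compounds than this note shows. Statements on the series, on what has been measured and on what is new or still open speak of the compounds shown alone.

Measured so far:
compound 1, `CCc1nc2c(-c3ccc(Cl)cc3Cl)ccnc2n1[C@@H](CC)C1CC1` — 0.4 nM
compound 2, `CCCC(C)n1c(CC)nc2c(-c3ccc(/C(C)=N\OC)cc3Cl)ccnc21` — 2.3 nM
compound 3, `CCC(CCOC)n1c(COC)nc2c(-c3ccc(C(F)(F)F)cc3Cl)ccnc21` — 82.7 nM

These three compounds were tested in an assay for binding affinity to Corticotropin releasing factor receptor (Rattus norvegicus); on this read-out lower numbers stand for stronger inhibition and higher numbers for weaker inhibition. Compound 1 gives 0.4 nM, compound 2 gives 2.3 nM, and compound 3 gives 82.7 nM. Compound 2 thus stands second highest of the three numbers: its nearest neighbour is compound 1, which lies lower by a margin beyond the usual scatter, and its furthest is compound 3, which lies higher by a margin well beyond it. Since no two of these compounds differ in only one place, no single step between them can be read off.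

Compound 4, `CCCC(C)n1c(CC)nc2c(-c3ccc(C(C)(C)O)cc3Cl)ccnc21`, differs from compound 2 in one place: a group of 4 heavy atoms (3 carbon, 1 oxygen; no ring) in place of a group of 5 heavy atoms (3 carbon, 1 nitrogen, 1 oxygen; no ring), on an aromatic carbon. The group enters meta to a chloro group and para to a large group. Nothing measured shows what this exchange does on its own, so the expected step is modest, toward a somewhat higher number, possibly within the scatter. The step from compound 2 to compound 4 is expected to be a 2.2-fold higher number from compound 2 to compound 4 (0.34 log units; beyond the scatter). Compound 4 is expected to give 5 nM in this assay, within a range from 1 nM to 25 nM.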

Compound 4, inhibition constant: 24 nM
Compound 4: middle estimate off by 4.8-fold (0.68 log units), on the low side, within the range that was stated.
By their numbers in this assay, from the lowest: compound 1; then compound 2; then compound 4; then compound 3.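

In this assay, this place on the aromatic ring, meta to a chloro group and para to a large group, proves sensitive to the exchange: replacing the oxime ether with 1-hydroxy-1-methylethyl gives a 10-fold higher number from compound 2 to compound 4 (1.02 log units; beyond the scatter), a large step for a change in one place. The two groups differ in more than one counted feature, as the oxime ether has a double bond outside aromatic rings and no hydrogen-bond donors, while 1-hydroxy-1-methylethyl has no such double bond and has a hydrogen-bond donor, so this single step cannot separate those features. No available evidence explains the size of the step.

The compounds shown leave open whether an isopropyl group or the methyl ether of the hydroxyl group would give a number closer to that of compound 2 or compound 4. They also leave open whether the same exchange would give a step of similar size with a different side chain on the shared core.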